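The source may report more compounds than this note shows. Statements on the series, on what has been measured and on what is new or still open speak of the compounds shown alone.

Measured so far in a functional assay on SN12C cells (Homo sapiens) for inhibition, read by sulforhodamine B assay, with a stated time of 48 h; a lower number here means a stronger inhibitor of growth, a higher number a weaker inhibitor of growth:

- compound 1 `O=C(Nc1cccc(-n2cc(-c3ccncc3)c(-c3ccc(Cl)c(O)c3)n2)c1)Nc1cccc(C(F)(F)F)c1`: > 32500 nM
- compound 2 `COc1cc(-c2nn(-c3cccc(NC(=O)c4cccc(C(F)(F)F)c4)c3)cc2-c2ccncc2)ccc1Cl`: > 50000 nM
- compound 3 `O=C(Nc1cccc(-n2cc(-c3ccncc3)c(-c3ccc(Cl)c(O)c3)n2)c1)Nc1cc(C(F)(F)F)cc(C(F)(F)F)c1`: 5450 nM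

Compound 2 `COc1cc(-c2nn(-c3cccc(NC(=O)c4cccc(C(F)(F)F)c4)c3)cc2-c2ccncc2)ccc1Cl` does not give a number in this assay; its value of > 50000 nM is a limit of the assay, one of the two limits that appear among the three values shown (the limit of > 50000 nM in this assay, at which 1 of the 3 values shown sits). The unmeasured compound 4 `COc1cc(-c2nn(-c3cccc(NC(=O)c4ccccc4)c3)cc2-c2ccncc2)ccc1Cl` differs from compound 2 in one place: hydrogen in place of trifluoromethyl on an aromatic carbon. Among the compounds with values here, the only measured step that bears on this change runs the other way. Adding a trifluoromethyl group gave an at least 5.9-fold lower number from compound 1 to compound 3 (0.77 log units; beyond the scatter), a step beyond the scatter, though on a different amide and a different trifluoromethylphenyl ring than in compound 2. Removing the trifluoromethyl group is therefore expected to move the number upward, if it moves it at all, and since compound 2 already stands at a limit, compound 4 is expected to remain at or beyond that limit, an estimated step that the limit leaves unreadable from compound 2 to compound 4. Compound 4 is estimated at 90000 nM in this assay, within 40000 nM to 250000 nM.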

Compound 4, concentration for total growth inhibition: > 100000 nM
Compound 4 was reported as a limit (the forecaster's own chance of this, stated with the estimate: 90%); at least 1.1-fold (0.04 log units) between middle value and limit.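

Compound 2 and compound 4 both sit at limits of this assay rather than at numbers, so the step between them cannot be read. The compounds shown leave open whether going from 3-(trifluoromethyl)phenyl to phenyl on this amide changes growth inhibition at all.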